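Ring-Closing the Amine Side Group of a Serotonin Receptor Agonist

The source may report more compounds than this note shows. Statements on the series, on what has been measured and on what is new or still open speak of the compounds shown alone.

Compound 1 `CC(=O)Nc1ccc([C@H](C)NCC2CCN(CCCc3c[nH]c4ccc(-n5cnnc5)cc34)CC2)cc1`: 3 nM
Compound 2 `C[C@H](NC1CCN(CCCc2c[nH]c3ccc(-n4cnnc4)cc23)CC1)c1ccccc1`: 12 nM

Both compounds were tested in an assay on CHO cells for agonist activity at 5-hydroxytryptamine receptor 1D (Homo sapiens), read by GTPgammaS binding; a higher number here means that more compound is needed for the effect, a lower number that less compound is needed. Of the two, compound 2 has the higher number, and its nearest neighbour, compound 1, gives 3 nM, a gap that is beyond the usual scatter. Compound 3 `c1ccc2c(c1)CCC2NCC1CCN(CCCc2c[nH]c3ccc(-n4cnnc4)cc23)CC1` is still to be measured. Relative to compound 2 the change is ((2,3-dihydro-1H-inden-1-yl)amino)methyl in place of (1-phenylethyl)amino on a saturated ring carbon. For the measured compounds named here, no measured pair isolates this single change, so any expectation rests on the two values shown. Going by these compounds, compound 1, whose side chain differs from that of compound 2 in more than one place, reaches the lower number, which suggests room for improvement in this region of the molecule, yet the new group is untested. The step of a 2.4-fold lower number from compound 2 to compound 3 (0.38 log units; beyond the scatter) is expected to be modest, toward a lower number, and possibly within the scatter. Compound 3 is estimated to give 5 nM, with a range from 1.5 nM to 15 nM.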

Compound 3, half-maximal effective concentration: 1.3 nM
Compound 3: the middle estimate sits 3.8-fold (0.59 log units) above what was measured; the measured number lies below the stated range.
By their numbers in this assay, from the lowest: compound 3; then compound 1; then compound 2.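

In this assay, placing ((2,3-dihydro-1H-inden-1-yl)amino)methyl on the saturated ring carbon gives a 9.2-fold lower number from compound 2 to compound 3 (0.97 log units; beyond the scatter) and so shows that this position can take a larger, ring-closed group and still need less compound. The second comparison gives a 2.3-fold lower number from compound 1 to compound 3 (0.36 log units; beyond the scatter) when 2,3-dihydro-1H-inden-1-yl replaces 1-(4-acetamidophenyl)ethyl on the amine nitrogen, so an acetamido group is not required for a low number here. Nothing shown explains either step.

The first step swaps a whole group, so the effect of closing the five-membered ring cannot be separated from that of the added methyl link. Also open, going by these compounds, is whether a 1,2,3,4-tetrahydronaphthalen-1-yl group, with a six-membered ring in place of the five-membered one, would lower the number further.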